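Ring in place of chain on the aromatic nitrogen

The source may hold more compounds than are shown below. What is called first, only, known or untested is meant among the compounds shown, and "the series" means these compounds.

Compound 1, `CCCCC(O)Cn1cc(CN(C)CC2CCCCC2)nn1`, gives 47% in an assay on nucleic acid for inhibition of Nucleic Acid, read by fluorescence, tested at 100 uM; on this read-out lower numbers stand for less inhibition and higher numbers for more inhibition at the one concentration tested (going by the name of the read-out).
Compound 2, `CN(Cc1cn(C2CCCCC2O)nn1)CC1CCCCC1`, gives 47% in this assay.
Compound 3, `CCCCC(O)Cn1cc(CN(CCCC)CCCC)nn1`, gives 18% in this assay.

Compound 1 and compound 2 differ in one place: 2-hydroxycyclohexyl in place of 2-hydroxyhexyl on an aromatic nitrogen. That exchange made no change at the digits printed from compound 1 to compound 2 (within the scatter). How the core of compound 3 differs from that of compound 1 is not broken down here; what the values show is that compound 3 stands lowest of the three, beyond the scatter from both compound 1 and compound 2.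

Compound 4, `CCCCN(CCCC)Cc1cn(C2CCCCC2O)nn1`, has not yet been measured. It relates to compound 3 by the same change that turns compound 1 into compound 2: 2-hydroxycyclohexyl in place of 2-hydroxyhexyl on an aromatic nitrogen. The step of a number 1 percentage points higher from compound 3 to compound 4 (within the scatter) is expected to be about as small, because the same exchange gave no change at the digits printed from compound 1 to compound 2 (within the scatter). Compound 4 is therefore estimated to give 19% in this assay, most likely between 6% and 33%.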

Compound 4, a percentage reported as inhibition, at one concentration (the size of the read-out at that concentration, not a potency): 32%
Estimate against measurement, compound 4: 13 percentage points below, within the range that was stated.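

In this assay, 2-hydroxycyclohexyl in place of 2-hydroxyhexyl gave a number 14 percentage points higher from compound 3 to compound 4 (beyond the scatter). Set beside the same exchange on the other core, the two steps cannot be told apart: the same change on two cores in this assay, no change at the digits printed (within the scatter) from compound 1 to compound 2 and a number 14 percentage points higher (beyond the scatter) from compound 3 to compound 4, 14 percentage points apart, within the scatter of two such steps. The change can therefore be said to carry across these two cores as far as the numbers can tell, but this does not show that the steps are truly equal, and two cores are too few to establish a rule for the series.

The compounds shown leave open what a plain cyclohexyl without the hydroxyl would give on the aromatic nitrogen. They also leave open whether the exchange behaves the same way on a core carrying a piperidine in place of the amine.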